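The source may hold more compounds than are shown below. What is called first, only, known or untested is meant among the compounds shown, and "the series" means these compounds.

Measured compounds:
compound 1 `Cc1ccc(-n2nccn2)c(C(=O)N2C[C@H](C#Cc3ccc(CO)nc3)CC[C@H]2C)c1` — "not determined" (no result reported) in a functional assay on isolated protein for antagonist activity at Orexin receptor type 2 (Homo sapiens), read by FLIPR and calcium flux; a higher number here means a weaker inhibitor, a lower number a stronger inhibitor
compound 2 `Cc1ccc(-n2nccn2)c(C(=O)N2C[C@H](/C=C/c3ccc(F)cn3)CC[C@H]2C)c1` — 34 nM
compound 3 `Cc1ccc(-n2nccn2)c(C(=O)N2C[C@H](C#Cc3cncc(CO)c3)CC[C@H]2C)c1` — "not determined" (no result reported)

For the measured compounds named here, compound 2 stands as the only compound with a number in this assay; compound 1 and compound 3 carry no reported value, so nothing can be said of them. Compound 4 `Cc1ccc(-n2nccn2)c(C(=O)N2C[C@H](C#Cc3ccc(F)cn3)CC[C@H]2C)c1` has not yet been measured. It differs from compound 2 in one place: 2-(5-fluoropyridin-2-yl)ethynyl in place of 2-(5-fluoropyridin-2-yl)ethenyl on a saturated ring carbon. Going by the values given here, no step between two measured compounds is available to calibrate this change. With one triple bond replacing one double bond outside aromatic rings and all else held, the step of a 1.2-fold higher number from compound 2 to compound 4 (0.07 log units; within the scatter) is expected to stay within the scatter, with no clear direction. Compound 4 is therefore estimated at 40 nM, within 15 nM to 120 nM.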

Compound 4, half-maximal inhibitory concentration: 24 nM
Compound 4: middle estimate off by 1.7-fold (0.22 log units), on the high side, and the stated range covers the measured number.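

In this assay, for the compounds shown here, the step at this saturated ring carbon, a 1.4-fold lower number from compound 2 to compound 4 (0.15 log units; within the scatter), gives the first reading of this change: 2-(5-fluoropyridin-2-yl)ethynyl and 2-(5-fluoropyridin-2-yl)ethenyl are not told apart here. Nothing available accounts for the result.

Steps involving compound 1 and compound 3 cannot be read, since neither carries a number. Still open, as far as these compounds go, is whether a saturated ethyl chain in place of the ethynyl, or an amine or carboxylic acid in place of the fluorine, would hold the number in this range.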